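The source may report more compounds than this note shows. Statements on the series, on what has been measured and on what is new or still open speak of the compounds shown alone.

The work measures inhibition in a functional assay on HepG2 cells (Homo sapiens) for inhibition, read by MTT assay, with a stated time of 72 h; on this read-out lower numbers stand for stronger inhibition and higher numbers for weaker inhibition. Compound 1 `CC(C)n1ncc2c(C(=O)NCc3cn(-c4cccc(F)c4)nn3)cccc21` gives only a limit of the assay, > 40000 nM, not a number. Compound 2 `CC(C)n1ncc2c(C(=O)NCc3cn(Cc4ccccc4)nn3)cccc21` gives 13700 nM in this assay, the only number shown. The other entry is the limit (the limit of > 40000 nM in this assay, at which 1 of the 2 values shown sits). For the measured compounds named here, the single measured step is an at least 2.9-fold lower number from compound 1 to compound 2 (0.46 log units; beyond the scatter), which lies beyond the scatter.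

Compound 3 `CC(C)n1ncc2c(C(=O)NCc3cn(Cc4ccc(C(F)(F)F)cc4)nn3)cccc21` differs from compound 2 by trifluoromethyl in place of hydrogen on an aromatic carbon. Going by the values given here, no measured step touches this position. The step of an at least 2.9-fold lower number from compound 1 to compound 2 (0.46 log units; beyond the scatter) concerns the group on the aromatic nitrogen and was at least modest, but it says nothing about a substituent on an aromatic carbon of the benzyl group. Among the compounds with values here, with no comparable step among the measured compounds, no change beyond the scatter is expected in this assay, though the closeness of compound 2 to the limit leaves room for the assay to report only a limit again. For compound 3 the expected step is a 1.2-fold lower number from compound 2 to compound 3 (0.10 log units; within the scatter). Compound 3 is therefore estimated to give 11000 nM in this assay, with a range from 3500 nM to 40000 nM.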

Compound 3, half-maximal inhibitory concentration: > 40000 nM
Compound 3: no number, only a limit; the forecaster's own chance of this, stated with the estimate: 20%; at least 3.6-fold (0.56 log units) between middle value and limit.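

For the compounds shown here, until now, the only measured change concerned the group on the aromatic nitrogen, and this result gives the first reading for the aromatic carbon of the benzyl group, para to a large group. In this assay, trifluoromethyl in place of hydrogen at this carbon is not a silent change, since it gives an at least 2.9-fold higher number from compound 2 to compound 3 (0.46 log units; beyond the scatter), and because compound 3 yields only a limit of the assay, the full size of that step cannot be read. Compound 2 therefore remains the only compound with a number, and the single-place changes linking it to compound 1 and compound 3 both meet the same limit: the limit of > 40000 nM in this assay, at which 2 of the 3 values shown sit.

The compounds shown leave open whether the effect belongs to trifluoromethyl itself or would also appear with fluorine, a methoxy group or an amine on the same carbon, and whether moving trifluoromethyl to another carbon of that ring would restore a measurable number. They also leave open whether a longer chain in place of benzyl on the aromatic nitrogen would give a lower number than compound 2 does.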